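A few compounds are considered here, and "the series" means these few. Any claim that something is new, unique, unknown or untested is made for them only; others in the source may bear on it.

In an assay on isolated protein for inhibition of Polyunsaturated fatty acid 5-lipoxygenase (Homo sapiens), read by HPLC, with stated times of 15 min and 10 min (a lower number here means a stronger inhibitor, a higher number a weaker inhibitor), compound 1 `COC1=CC(=O)C(=O)C(CCCCCCCCO)=C1OC` gives 150 nM, and compound 2 `COC1=CC(=O)C(=O)C(CCCCCCCCCCO)=C1OC` gives 360 nM. Compound 3 `COC1=CC(=O)C(OC)=C(CCCCCCCCO)C1=O` gives 330 nM in this assay; that number sits within the scatter of the value of compound 2, while its gap to compound 1 is beyond the scatter, with compound 1 giving the lower number. Compound 4 `COC1=CC(=O)C(OC)=C(CCCCCCCCCCO)C1=O` has not yet been measured. It differs from compound 3 by 2-hydroxyethyl in place of hydroxy on a saturated chain carbon, eight bonds along the chain from a double-bonded ring carbon. The same change has been measured once, as a 2.4-fold higher number from compound 1 to compound 2 (0.38 log units; beyond the scatter), a modest rise. The step from compound 3 to compound 4 is therefore expected to be of similar size and in the same direction, namely a 2.4-fold higher number from compound 3 to compound 4 (0.38 log units; beyond the scatter). Compound 4 is thus estimated at 790 nM, with a likely range from 350 nM to 1800 nM.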

Compound 4, half-maximal inhibitory concentration: 550 nM
Compound 4: middle estimate off by 1.4-fold (0.16 log units), on the high side; the measured number falls inside the stated range.
By their numbers in this assay, from the lowest: compound 1; then compounds 3, 2 and 4 (each within the scatter of the next).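

On the core of compound 3, the same change gives a 1.7-fold higher number from compound 3 to compound 4 (0.22 log units; within the scatter) and so, unlike on the core of compound 1, cannot be told apart from the usual scatter of repeated measurements. Even so, the two cores do not show a real difference in how they respond to this change: the same change on two cores in this assay, a 2.4-fold higher number (0.38 log units; beyond the scatter) from compound 1 to compound 2 and a 1.7-fold higher number (0.22 log units; within the scatter) from compound 3 to compound 4, 1.4-fold (0.16 log units) apart, within the scatter of two such steps.

With only two chain lengths on each core, the compounds shown leave open how the numbers run with a longer chain. They also leave open what a carboxylic acid or an amine would give in place of the hydroxy.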